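The compounds below may be only part of what the source reports. "The series", "measured", "known", "first", "only" and "open" are said of these compounds alone.

Working notes on the series. In a functional assay on the whole organism with Rattus norvegicus as the target (a higher number here means that more compound is needed for the effect, a lower number that less compound is needed), compound 1 (`CCOCCOC(=O)C(=O)Nc1nc(-c2cc(Cl)no2)cs1`) gives 6 mg/kg and compound 2 (`CC(C)(C)OC(=O)C(=O)Nc1nc(-c2cc(-c3ccccc3)no2)cs1`) gives 9 mg/kg so the two stand together within the usual scatter. For the measured compounds named here, these are the only two true numbers so far. Compound 3 (`O=C(Nc1nc(-c2cc(-c3c(F)cccc3Cl)no2)cs1)C(=O)OCc1ccccc1`) returns only a limit (> 30 mg/kg) and gives no number to compare.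

The next compound to read is compound 4 (`CCOCCOC(=O)C(=O)Nc1nc(-c2cc(CO)on2)cs1`). It differs from compound 1 in one place (5-(hydroxymethyl)-1,2-oxazol-3-yl in place of 3-chloro-1,2-oxazol-5-yl on an aromatic carbon) with 5-(hydroxymethyl)-1,2-oxazol-3-yl in place of 3-chloro-1,2-oxazol-5-yl on an aromatic carbon of the shared core. The rest of the structure of compound 1 stays as it is.

Going by the values given here, no two measured compounds differ in a single place, so the series offers no direct guide to this change, and any expectation is loose. A moderate step toward a higher number is expected (a 2.0-fold higher number from compound 1 to compound 4 (0.30 log units; within the scatter)) and it may not clear the scatter by much. A report of a limit alone also remains possible in this assay for this compound. The estimated value for compound 4 is 12 mg/kg with an expected range from 4 mg/kg to 30 mg/kg as the working figure until the measurement is in.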

Compound 4, dose for half-maximal effect: 1.8 mg/kg
Compound 4: the middle estimate sits 6.7-fold (0.82 log units) above what was measured; measured number below the stated range.
By their numbers in this assay, from the lowest: compound 4; then compounds 1 and 2 (each within the scatter of the next). At a limit, above all of these: compound 3.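

For the compounds shown here, with 5-(hydroxymethyl)-1,2-oxazol-3-yl in place of 3-chloro-1,2-oxazol-5-yl on an aromatic carbon of the shared core, this assay records a 3.3-fold lower number from compound 1 to compound 4 (0.52 log units; beyond the scatter), the only step so far that can be read between compounds differing in one place. This position, next to the ring nitrogen and two ring bonds from the ring sulfur, therefore accepts a group with a hydrogen-bond donor and no chlorine, and the number moves down rather than up. Nothing measured in the series bears on why this step goes in this direction.

The exchange alters the point of attachment of the 1,2-oxazole, removes the chlorine and adds the hydroxymethyl all at once, and the compounds shown do not separate these three changes. Also open, from the compounds shown here alone, is whether an aminomethyl group, a carboxylic acid or a longer hydroxyalkyl chain in place of the hydroxymethyl would keep the step, and whether the 5-(hydroxymethyl)-1,2-oxazol-3-yl group gives a similar step alongside the tert-butyl or benzyl esters.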